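Swapping a fluorophenyl for a pyridyl on the amide arm

This account rests on a few compounds, and the source may have more. Where it says the series, first, only, none or still open, it means among the compounds named here.

Measured so far in a functional assay on SK-OV-3 cells (Homo sapiens) for cytotoxicity, read by MTT assay, with a stated time of 48 h; a higher number here means a weaker inhibitor, a lower number a stronger inhibitor:
compound 1 `COc1ccc(CNC(=O)CC2c3ccccc3N=C(N(C)CCCCCN(C)C)N2c2ccc(-c3ccccc3)cc2)cc1`: 4460 nM
compound 2 `CN(C)CCCCCCN(C)C1=Nc2ccccc2C(CC(=O)NCc2ccccc2)N1c1ccc(-c2ccccc2)cc1`: 5780 nM
compound 3 `CN(C)CCN1CCN(C2=Nc3ccccc3C(CC(=O)NCc3ccc(F)cc3)N2c2ccc(-c3ccccc3)cc2)CC1`: 3090 nM

All three compounds share one core and differ in the side chains hanging from it. Compound 3 has the smallest of the three numbers in this assay, but its gaps to compound 1 and to compound 2 both lie within the usual scatter of repeated measurements, so the three cannot be told apart on these data. Among the measured compounds shown here, no pair of compounds differs in just one place, so no single step has been measured.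

Compound 4 `CN(C)CCN1CCN(C2=Nc3ccccc3C(CC(=O)NCc3ccncc3)N2c2ccc(-c3ccccc3)cc2)CC1` has not yet been tested. It is compound 3 with one change: pyridin-4-yl in place of 4-fluorophenyl on a saturated chain carbon bound to an amide-type nitrogen. For the measured compounds named here, nothing among the measured compounds shows what such a swap does here, so the expected step from compound 3 to compound 4 is small, with no clear direction beyond the scatter, namely a 1.1-fold higher number from compound 3 to compound 4 (0.05 log units; within the scatter). Compound 4 is therefore estimated to give 3500 nM in this assay, with a range from 1500 nM to 8000 nM.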

Compound 4, half-maximal inhibitory concentration: 11700 nM
Compound 4: the middle estimate sits 3.3-fold (0.52 log units) below what was measured; measured number outside the range, above it.
By their numbers in this assay, from the lowest: compounds 3, 1 and 2 (each within the scatter of the next); then compound 4.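

In this assay the amide arm proves sensitive to which ring it carries: pyridin-4-yl in place of 4-fluorophenyl brings a 3.8-fold higher number from compound 3 to compound 4 (0.58 log units; beyond the scatter) and so a weaker inhibitor. Among the compounds shown here, this is the first single change that can be read in this set, and it shows that a swap of one aromatic ring for another of similar size on this arm can move the number beyond the scatter. Nothing measured here explains the loss.

Going by these compounds, it remains open whether the ring nitrogen or the missing fluorine matters more, and a pyridin-3-yl or a 4-chlorophenyl on the same arm could help to separate the two. Whether the same swap has a similar effect alongside the open-chain diamine arms of compound 1 and compound 2 is also unknown.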